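A few compounds are considered here, and "the series" means these few. Any claim that something is new, unique, unknown or untested is made for them only; others in the source may bear on it.

Measured compounds:
compound 1 `O=c1sc2ccccc2n1CCCCCN1CCCCCC1`: 7 nM
compound 2 `O=c1sc2ccccc2n1CCCCCCN1CCCCCC1`: 7.5 nM
compound 3 `CCCc1ccc2c(c1)sc(=O)n2CCCN1CCCCCC1`: 1.4 nM

In an assay on cell membranes for displacement of a labelled ligand from Sigma non-opioid intracellular receptor 1 (Rattus norvegicus) (on this read-out higher numbers stand for weaker inhibition and lower numbers for stronger inhibition), compound 2 gives 7.5 nM, the highest of the three numbers. Compound 1 gives 7 nM in this assay, a value within the scatter of that of compound 2, so the two cannot be told apart. Compound 3 gives 1.4 nM, which lies beyond the scatter below the value of compound 2; compound 3 differs from compound 2 both in the chain on the ring nitrogen and in the substituent on the aromatic ring, so no single change accounts for the gap.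

Compound 4 `CCCCc1ccc2c(c1)sc(=O)n2CCCCCCN1CCCCCC1` has not yet been measured in this assay. It arises from compound 2 by butyl in place of hydrogen on an aromatic carbon. Since compound 3, which also carries an alkyl group on the aromatic ring, shows the lowest number, a step toward lower numbers is expected for compound 4, of a size near the edge of the scatter. The estimated step is a 2.1-fold lower number from compound 2 to compound 4 (0.33 log units; beyond the scatter). Compound 4 is therefore expected to give about 3.5 nM, within a range from 0.9 nM to 14 nM.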

Compound 4, inhibition constant: 12 nM
The estimate for compound 4 lay 3.4-fold (0.54 log units) below the measured number, and the stated range covers the measured number.
By their numbers in this assay, from the lowest: compound 3; then compounds 1, 2 and 4 (each within the scatter of the next).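

In this assay, among these compounds, compound 2 and compound 4 give the first reading of this change on its own: butyl in place of hydrogen on an aromatic carbon gives a step within the scatter (a 1.6-fold higher number from compound 2 to compound 4 (0.20 log units; within the scatter)). With the chain of compound 2 held fixed, this aromatic carbon therefore carries butyl, with its 4 heavy atoms and no ring, without a change that can be told from repeat measurements. Nothing at hand explains this outcome.

On these data alone, whether an amine, a carboxylic acid or a methoxy group on this aromatic carbon would shift the number remains open. So does whether butyl would also leave the number within the scatter on the chain of compound 3, whose own value cannot be assigned to a single change.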